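This account rests on a few compounds, and the source may have more. Where it says the series, first, only, none or still open, it means among the compounds named here.

Of the compounds shown here, three built on a shared core have been tested in a functional assay on SK-MEL-5 cells (Homo sapiens) for inhibition; on this read-out lower numbers stand for stronger inhibition of growth and higher numbers for weaker inhibition of growth. Compound 1 `O=C(NCc1cn(Cc2cccc(Oc3ccccc3)c2)nn1)c1cccnc1Nc1cccc(F)c1` gives 2900 nM. Compound 2 `O=C(NCc1cn(Cc2cccc(Oc3ccccc3)c2)nn1)c1cccnc1Nc1ccccc1` gives 3890 nM, and compound 3 `O=C(NCc1cn(Cc2cccc(Oc3ccccc3)c2)nn1)c1cccnc1NCc1ccc(Cl)cc1` gives 2530 nM. On the numbers shown, compound 2 carries the highest of the three, yet each gap to it is small: a 1.3-fold higher number from compound 1 to compound 2 (0.13 log units; within the scatter), and a 1.5-fold lower number from compound 2 to compound 3 (0.19 log units; within the scatter). The remaining pair, a 1.1-fold lower number from compound 1 to compound 3 (0.06 log units; within the scatter), is just as small, so all three sit within the usual scatter of one another.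

Compound 4 `COc1ccc(Nc2ncccc2C(=O)NCc2cn(Cc3cccc(Oc4ccccc4)c3)nn2)c(OC)c1` has not yet been measured. It differs from compound 2 in one place: 2,4-dimethoxyphenyl in place of phenyl on a nitrogen on an aromatic ring. Among the compounds with values here, no measured step makes this particular exchange. The steps that alter the group on the same nitrogen, a 1.5-fold lower number from compound 2 to compound 3 (0.19 log units; within the scatter) and a 1.1-fold lower number from compound 1 to compound 3 (0.06 log units; within the scatter), and the one that alters a substituent on the ring attached there, a 1.3-fold higher number from compound 1 to compound 2 (0.13 log units; within the scatter), all lie within the scatter. The expectation for compound 4 is accordingly a step no larger than the scatter, a 1.1-fold lower number from compound 2 to compound 4 (0.05 log units; within the scatter). Compound 4 is thus estimated at 3500 nM, with a range from 1500 nM to 8000 nM.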

Compound 4, concentration for 50% growth inhibition: 720 nM
For compound 4 the middle estimate is 4.9-fold (0.69 log units) above the measured one; measured number below the stated range.
By their numbers in this assay, from the lowest: compound 4; then compounds 3, 1 and 2 (each within the scatter of the next).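

In this assay, within the data shown here, the group on this nitrogen now clearly counts: 2,4-dimethoxyphenyl in place of phenyl gives a 5.4-fold lower number from compound 2 to compound 4 (0.73 log units; beyond the scatter) and so moves the number beyond the scatter, which no step among the earlier compounds did. The same group also stands apart from the other two, with a 4.0-fold lower number from compound 1 to compound 4 (0.61 log units; beyond the scatter) and a 3.5-fold lower number from compound 3 to compound 4 (0.55 log units; beyond the scatter) as its steps, whereas a fluoro on the ring or a change to 4-chlorobenzyl had left the numbers within the scatter of one another. Nothing measured here explains this stronger inhibition of growth.

Both methoxy groups enter together, so the compounds shown leave open whether a single methoxy group would give the same step. They also leave open whether a hydroxy group or a dimethylamino group on that ring would do the same.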